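The compounds below may be only part of what the source reports. "The series", "measured", "known", "first", "only" and "open" are said of these compounds alone.

Compound 1 `FC(F)(F)c1ccc(Nc2nc(N3CCC3)nc3sc(Nc4c(Cl)cccc4Cl)nc23)cc1` gives 25 nM in a functional assay on HEK293 cells for antagonist activity at transient receptor potential cation channel subfamily V member 1 (Rattus norvegicus), read by calcium flux; a lower number here means a stronger inhibitor, a higher number a weaker inhibitor. Compound 2 `CCN(CC)c1nc(Nc2ccc(C(F)(F)F)cc2)c2nc(Nc3c(Cl)cccc3Cl)sc2n1` gives 34 nM and stands with the higher of the two numbers; the step of a 1.4-fold higher number from compound 1 to compound 2 (0.13 log units; within the scatter) stays within the scatter. Compound 3 `CC(C)Nc1nc(Nc2ccc(C(F)(F)F)cc2)c2nc(Nc3c(Cl)cccc3Cl)sc2n1` carries the change (isopropylamino in place of diethylamino on an aromatic carbon). Among the measured compounds shown here, the only step available at that carbon, a 1.4-fold higher number from compound 1 to compound 2 (0.13 log units; within the scatter), swapped one amine for another and moved little, so no step beyond the scatter is expected in this assay for compound 3, in either direction; the expected step is a 1.2-fold higher number from compound 2 to compound 3 (0.07 log units; within the scatter). Compound 3 is accordingly estimated at 40 nM, with an expected range of 15 nM to 110 nM.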

Compound 3, half-maximal inhibitory concentration: 9 nM
Beside the measured number, compound 3's estimate is 4.4-fold (0.65 log units) above it, and the stated range ends above it.
By their numbers in this assay, from the lowest: compound 3; then compounds 1 and 2 (each within the scatter of the next).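

At this carbon, between two ring nitrogen atoms, the choice of amine does matter in this assay: isopropylamino gives a 3.8-fold lower number from compound 2 to compound 3 (0.58 log units; beyond the scatter) and a 2.8-fold lower number from compound 1 to compound 3 (0.44 log units; beyond the scatter), whereas the earlier swap stayed within the scatter. Isopropylamino carries 1 hydrogen-bond donor, while diethylamino carries 0 hydrogen-bond donors, but the data do not tie the step to that difference. Nothing measured here bears on the reason for the step.

On these data alone, whether the step follows the hydrogen on the nitrogen or the branched chain stays open. Methylamino, cyclopropylamino and isopropyl(methyl)amino groups would help separate the two.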